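This account rests on a few compounds, and the source may have more. Where it says the series, first, only, none or still open, it means among the compounds named here.

Going by the values given here, compound 2 `COc1ccccc1N1CCN(CCCCNC(=O)c2ccc(-c3ccsc3)cc2)CC1` stands at the lowest of the two numbers measured so far: in an ADME assay on microsomes from liver (Rattus norvegicus) for metabolic stability, read by LC-MS, using NADPH (a higher number here means that the compound lasts longer, a lower number that the compound disappears faster), compound 2 gives 0.04 h. Among the compounds with values here, its only neighbour is compound 1 `O=C(NCCCCN1CCN(c2ccccc2)CC1)c1ccc(-c2ccsc2)cc1`, which in this assay gives 0.41 h, and the one measured step, a 10-fold lower number from compound 1 to compound 2 (1.01 log units; beyond the scatter), is the whole of what is known about this series.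

Compound 3 `O=C(NCCCCN1CCN(c2ccc(O)cc2)CC1)c1ccc(-c2ccsc2)cc1` has not yet been measured. Its change from compound 2 is 4-hydroxyphenyl in place of 2-methoxyphenyl on an amine nitrogen in a ring. Within the data shown here, the methoxy that entered from compound 1 to compound 2 leaves again, so the step of a 10-fold lower number from compound 1 to compound 2 (1.01 log units; beyond the scatter) bears on it directly and points back upward; at the same time a hydroxyl enters at the 4-position, for which no measured step exists, so its effect on the half-life is unknown.

Compound 3 is therefore expected to give a number that rises clearly from compound 2, the step of a 6.3-fold higher number from compound 2 to compound 3 (0.80 log units; beyond the scatter) being expected, with a best estimate of 0.25 h and a range from 0.08 h to 0.8 h.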

Compound 3, half-life: 0.19 h
Beside the measured number, compound 3's estimate is 1.3-fold (0.12 log units) above it, and the stated range covers the measured number.
By their numbers in this assay, from the lowest: compound 2; then compound 3; then compound 1.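

Exchanging 2-methoxyphenyl for 4-hydroxyphenyl on the amine nitrogen in the ring gives a 4.8-fold higher number from compound 2 to compound 3 (0.68 log units; beyond the scatter) in this assay, so the short half-life of compound 2 is not shared by every substituted phenyl in this series. The hydroxy compound still does not return to the level of the unsubstituted phenyl: putting a hydroxyl on the plain phenyl gives a 2.2-fold lower number from compound 1 to compound 3 (0.33 log units; beyond the scatter), a smaller fall than a 10-fold lower number from compound 1 to compound 2 (1.01 log units; beyond the scatter), and among these three compounds both substituted phenyl groups therefore last less long than the plain phenyl of compound 1, with no compound going against this. Nothing at hand gives a reason for either fall or for the gap between them.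

The step from compound 2 to compound 3 changes both the group and the place it sits on the phenyl, so the compounds shown cannot separate these two changes; 4-methoxyphenyl and 2-hydroxyphenyl would each alter only one of them. They also leave open whether a smaller group such as fluoro on the phenyl would lower the half-life as well, and how a longer chain would behave.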